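Benzyl-substituted adenosine analogues: a weakly active series

The source may hold more compounds than are shown below. What is called first, only, known or untested is meant among the compounds shown, and "the series" means these compounds.

Compound 1 `OC[C@H]1O[C@@H](n2cnc3c(NCc4cccc(Br)c4)ncnc32)[C@H](O)[C@@H]1O` sits at the limit of a functional assay on G-361 cells (Homo sapiens) for antiproliferative activity, with a stated time of 72 h (a lower number here means a stronger inhibitor, a higher number a weaker inhibitor), reported as > 166000 nM.
Compound 2 `Cc1cccc(CNc2ncnc3c2ncn3[C@@H]2O[C@H](CO)[C@@H](O)[C@H]2O)c1` also sits at the limit of this assay, reported as > 166000 nM.
Compound 3 `OC[C@H]1O[C@@H](n2cnc3c(NCc4ccc(Cl)c(Cl)c4)ncnc32)[C@H](O)[C@@H]1O` gives a number in this assay, 145000 nM.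

Among the compounds with values here, compound 3 is the only member of the series with a measured half-maximal inhibitory concentration; the other two values are limits, (the limit of > 166000 nM in this assay, at which 2 of the 3 values shown sit). Both steps to compound 3 are therefore only floors: an at least 1.1-fold lower number from compound 1 to compound 3 (0.05 log units; that floor lies within the scatter) and an at least 1.1-fold lower number from compound 2 to compound 3 (0.05 log units; that floor lies within the scatter). The step that the two limits leave unreadable from compound 1 to compound 2 cannot be read at all.

Compound 4 `OC[C@H]1O[C@@H](n2cnc3c(NCc4cccc(O)c4O)ncnc32)[C@H](O)[C@@H]1O` differs from compound 3 in one place: 2,3-dihydroxyphenyl in place of 3,4-dichlorophenyl on a saturated chain carbon bound to a nitrogen on an aromatic ring.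

Within the data shown here, no measured step covers a change of this kind. The three measured compounds, with bromo, methyl, and dichloro substituents on the benzyl ring, all sit at or just below the limit, so the series shows no room in which the dihydroxy change could register a readable gain or loss. The expectation for compound 4 is thus no step beyond the scatter, a 1.1-fold higher number from compound 3 to compound 4 (0.06 log units; within the scatter), with a substantial chance that only a limit is reported. Compound 4 is estimated at 166000 nM in this assay, within 80000 nM to 500000 nM.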

Compound 4, half-maximal inhibitory concentration: 16900 nM
Compound 4: middle estimate off by 9.8-fold (0.99 log units), on the high side; the measured number lies below the stated range.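

In this assay, replacing 3,4-dichlorobenzyl with 2,3-dihydroxybenzyl gives the series its first step of readable size: an 8.6-fold lower number from compound 3 to compound 4 (0.93 log units; beyond the scatter). This shows that a change on the benzyl ring, with the rest of the shared core held constant, can move the number beyond the scatter, which the bromo, methyl and dichloro compounds could not show. The same group compared with the 3-methylphenyl and 3-bromophenyl compounds gives an at least 9.8-fold lower number from compound 2 to compound 4 (0.99 log units; beyond the scatter) and an at least 9.8-fold lower number from compound 1 to compound 4 (0.99 log units; beyond the scatter), and these two steps are floors rather than full sizes: the limit of > 166000 nM in this assay, at which 2 of the 4 values shown sit.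

The step swaps two chlorines for two hydroxyl groups and also changes where the ring carries its substituents, so the compounds shown cannot separate the identity of the groups from their placement. Also open, on these data alone, is whether a single hydroxyl group would be enough, or whether methoxy or amino groups in place of the hydroxyl groups of the 2,3-dihydroxyphenyl ring would give a step of similar size.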